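The compounds below may be only part of what the source reports. "The series", "measured", "known", "first", "only" and "open" are said of these compounds alone.

Of the compounds shown here, three have so far been measured in a functional assay on PC-3 cells (Homo sapiens) for inhibition, read by MTT assay, with a stated time of 48 h; a higher number here means a weaker inhibitor, a lower number a stronger inhibitor. Compound 1 `COc1ccc(CN(c2cc(OC)c(OC)c(OC)c2)S(=O)(=O)c2ccc(C)cc2)cc1` gives 8220 nM in this assay, and compound 2 `COc1cc(N(Cc2ccccc2)S(=O)(=O)c2ccc(C)cc2)cc(OC)c1OC` gives 7810 nM. Within the data shown here, the only step between measured compounds that differ in a single place is a 1.1-fold lower number from compound 1 to compound 2 (0.02 log units; within the scatter), a change of hydrogen in place of methoxy on an aromatic carbon. Compound 3 `Cc1ccc(S(=O)(=O)N(Cc2nc3ccccc3[nH]2)c2ccccc2)cc1` stands apart from the other two. In this assay compound 3 gives only a limit, > 50000 nM, so no number is known for it. That limit is the one at which (the limit of > 50000 nM in this assay, at which 1 of the 3 values shown sits).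

The step to compound 4 `COc1ccc(N(Cc2nc3ccccc3[nH]2)S(=O)(=O)c2ccc(C)cc2)cc1` is methoxy in place of hydrogen on an aromatic carbon of a six-membered aromatic ring of carbon only, para to a large group; cut one bond further out, the change reads phenyl to 4-methoxyphenyl. The measured step that bears on it is a 1.1-fold lower number from compound 1 to compound 2 (0.02 log units; within the scatter), which moves a methoxy on an aromatic carbon the other way and stays within the scatter. Since compound 3 sits at the limit, the step from compound 3 to compound 4 can only be read as an expectation of no movement beyond the scatter, and the measurement of compound 4 is expected most likely to come back as a limit again. Compound 4 is expected to give about 50000 nM in this assay, within 20000 nM to 120000 nM, which means an expected step of a number no higher from compound 3 to compound 4 (the limit leaves the size open).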

Compound 4, half-maximal inhibitory concentration: > 50000 nM
Compound 4: only a limit was reported; the forecaster's own chance of this, stated with the estimate: 65%; the middle value lies on the limit itself.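

In this assay compound 4 gives > 50000 nM as a limit and not a number. Compound 3 also has only a limit, so no step can be read from compound 3 to compound 4: the limit of > 50000 nM in this assay, at which 2 of the 4 values shown sit. The compounds shown leave open whether methoxy in place of hydrogen changes the number at all on the core of compound 3.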